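The compounds below may be only part of what the source reports. "The series", "measured", "known", "first", "only" and "open" are said of these compounds alone.

Of the compounds shown here, three built on one shared core have been tested in an ADME assay on HEK293 cells (Homo sapiens) for cytotoxicity, read by CCK-8 assay, with a stated time of 4 days; on this read-out lower numbers stand for stronger inhibition and higher numbers for weaker inhibition. Compound 1 `Oc1ccc(-c2cc(-c3ccc(O)cc3)nc(-c3ccc(O)cc3)c2)cc1` gives 790 nM. Compound 2 `Oc1ccc(-c2cc(-c3cccc(O)c3)cc(-c3ccccc3O)n2)cc1` reaches only the limit of the assay, > 50000 nM, so no number is known for it. Compound 3 `Oc1ccc(-c2cc(-c3cccc(O)c3)nc(-c3ccccc3O)c2)cc1` gives 7420 nM, the highest of the two numbers shown; compound 1 sits well below it, and that gap is larger than the usual scatter. Compound 4 `Oc1ccc(-c2cc(-c3ccc(O)cc3)nc(-c3ccccc3O)c2)cc1` has not yet been measured. It differs from compound 3 in one place: 4-hydroxyphenyl in place of 3-hydroxyphenyl on an aromatic carbon. In structure this brings compound 4 closer to compound 1, which gives 790 nM. A step toward a lower number, modestly beyond the scatter, is therefore expected: a 2.5-fold lower number from compound 3 to compound 4 (0.39 log units; beyond the scatter). Compound 4 is estimated at 3000 nM, within 1000 nM to 9000 nM.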

Compound 4, half-maximal inhibitory concentration: 26300 nM
Compound 4: middle estimate off by 8.8-fold (0.94 log units), on the low side, and the stated range ends below it.
By their numbers in this assay, from the lowest: compound 1; then compound 3; then compound 4. At a limit, above all of these: compound 2.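

Putting 4-hydroxyphenyl in place of 3-hydroxyphenyl on the aromatic carbon next to the ring nitrogen moves the number away from that of compound 1, not toward it: a 3.5-fold higher number from compound 3 to compound 4 (0.55 log units; beyond the scatter). The larger step comes with the other swap, 2-hydroxyphenyl in place of 4-hydroxyphenyl: a 33-fold higher number from compound 1 to compound 4 (1.52 log units; beyond the scatter). Compound 2 stands at a limit of the assay, so its step gives only a floor: an at least 1.9-fold lower number from compound 2 to compound 4 (0.27 log units; that floor lies within the scatter).

From the compounds shown here alone, whether an amine or a carboxylic acid in place of the hydroxyl on this ring would shift the number stays open. The cause of these steps also stays open.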